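The compounds below may be only part of what the source reports. "The series", "measured", "known", "first", "only" and "open" are said of these compounds alone.

Compound 1 `O=C(CCCC1CCN(Cc2ccccc2)CC1)c1ncco1` gives 315 nM in an assay on isolated protein for inhibition of Fatty-acid amide hydrolase 1 (Homo sapiens); a lower number here means a stronger inhibitor, a higher number a weaker inhibitor. Compound 2 `O=C(CCCC1CCN(Cc2ccc(Cl)cc2)CC1)c1ncco1` gives 66 nM in this assay, and compound 3 `O=C(CCCC1CCN(Cc2ccccc2Br)CC1)c1ncco1` gives 315 nM. Among these three numbers compound 2 stands lowest: the step from compound 1 to compound 2 is a 4.8-fold lower number from compound 1 to compound 2 (0.68 log units; beyond the scatter), while the step from compound 1 to compound 3 is no change at the digits printed from compound 1 to compound 3 (within the scatter), and the step from compound 2 to compound 3 is a 4.8-fold higher number from compound 2 to compound 3 (0.68 log units; beyond the scatter). Compound 4 `CC(C)c1ccc(CN2CCC(CCCC(=O)c3ncco3)CC2)cc1` has not yet been measured. It differs from compound 2 by isopropyl in place of chloro on an aromatic carbon. Among the measured compounds shown here, the only measured step touching this same aromatic carbon is the one that put the chloro there, a 4.8-fold lower number from compound 1 to compound 2 (0.68 log units; beyond the scatter), so the step from compound 2 to compound 4 is expected to be small, a 1.2-fold lower number from compound 2 to compound 4 (0.08 log units; within the scatter), since a group again sits on that carbon and nothing measured shows how a larger one would behave. For compound 4 the estimate in this assay is 55 nM, with a range from 15 nM to 200 nM.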

Compound 4, half-maximal inhibitory concentration: 3.6 nM
Estimate against measurement, compound 4: 15-fold (1.18 log units) above; measured number outside the range, below it.
By their numbers in this assay, from the lowest: compound 4; then compound 2; then compounds 1 and 3 (each within the scatter of the next).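

In this assay, isopropyl in place of chloro on this aromatic carbon, para to a large group, gives an 18-fold lower number from compound 2 to compound 4 (1.26 log units; beyond the scatter) and shows that the kind of group here matters, not merely whether one is present. Measured from the unsubstituted compound, isopropyl gives an 88-fold lower number from compound 1 to compound 4 (1.94 log units; beyond the scatter) while chloro gave a 4.8-fold lower number from compound 1 to compound 2 (0.68 log units; beyond the scatter) and so the earlier gain at this carbon proves to be only part of what a substituent here can deliver. Nothing available explains why isopropyl, with its three carbon atoms, outdoes the single chlorine atom.

One pair of groups cannot separate the effect of heavy-atom count from that of the atoms themselves. The compounds shown leave open how a methyl, a tert-butyl or a methoxy group would behave at this carbon, and whether the gain with isopropyl would continue with a longer chain.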